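Methoxy in place of cyano: compound 3

This account rests on a few compounds, and the source may have more. Where it says the series, first, only, none or still open, it means among the compounds named here.

In a functional assay on MCF7 cells (Homo sapiens) for inhibition, read by sulforhodamine B assay, with a stated time of 48 h (on this read-out lower numbers stand for stronger inhibition of growth and higher numbers for weaker inhibition of growth), compound 1 `O=C1CC(c2ccc(F)cc2)Nc2c(Br)cc(Br)cc21` gives < 100 nM, which is a limit of the assay rather than a number. Compound 2 `N#Cc1ccc(C2CC(=O)c3cc(Br)cc(Br)c3N2)cc1` likewise gives < 100 nM, again a limit. The step that the two limits leave unreadable from compound 1 to compound 2 therefore cannot be read, as both values sit at the limit of < 100 nM in this assay, at which 2 of the 2 values shown sit. Compound 2 thus stands at the limit, with no number to place it. Compound 3 `COc1ccc(C2CC(=O)c3cc(Br)cc(Br)c3N2)cc1` carries methoxy in place of cyano on an aromatic carbon. Among the compounds with values here, the one measured step, from compound 1 to compound 2, offers no size to transfer. The expected step is a step that the limit leaves unreadable from compound 2 to compound 3, nothing beyond the scatter. Compound 3 is expected at 60 nM, within 10 nM to 300 nM.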

Compound 3, concentration for 50% growth inhibition: > 100000 nM
Compound 3: only a limit was reported; the forecaster's own chance of this, stated with the estimate: 60%; middle value at least 1600-fold (3.22 log units) away from the limit.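

In this assay compound 3 gives > 100000 nM, a limit of the assay and not a number. This position on the aromatic carbon is clearly sensitive to the group it carries: methoxy in place of cyano gives an at least 1000-fold higher number from compound 2 to compound 3 (3.00 log units; beyond the scatter), and methoxy in place of fluoro gives an at least 1000-fold higher number from compound 1 to compound 3 (3.00 log units; beyond the scatter). The earlier step from fluoro to cyano cannot be read and showed none of this: the limit of < 100 nM in this assay, at which 2 of the 3 values shown sit.

On these data alone, with limits at both ends, the true size of these steps stays open. So does how an amine or a longer chain such as ethoxy would read at this position.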